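Trifluoromethoxy for Methyl on the Core of Compound 1

A few compounds are considered here, and "the series" means these few. Any claim that something is new, unique, unknown or untested is made for them only; others in the source may bear on it.

Within the data shown here, compound 1 `Cc1ccc2c(c1)c(=O)c(C(=O)Nc1ccc(Oc3ncnc4[nH]cc(-c5ccccc5)c34)c(F)c1)c(C)n2C` gives 100 nM in an assay on isolated protein for inhibition of tyrosine-protein kinase receptor UFO (Homo sapiens), read by FRET and Z'-LYTE, with a stated time of 1.5 h (a lower number here means a stronger inhibitor, a higher number a weaker inhibitor), the lowest of the three numbers measured so far. Compound 3 `Cc1ccc2c(c1)c(=O)c(C(=O)Nc1ccc(Oc3ncnc4[nH]cc(-c5ccccc5)c34)c(F)c1)cn2C` gives 150 nM, and compound 2 `CCCn1c(C)c(C(=O)Nc2ccc(Oc3ncnc4[nH]cc(-c5ccccc5)c34)c(F)c2)c(=O)c2cc(C)ccc21` gives 530 nM. The step of a 1.5-fold higher number from compound 1 to compound 3 (0.18 log units; within the scatter), hydrogen in place of methyl on an aromatic carbon, stays within the scatter, whereas a 5.3-fold higher number from compound 1 to compound 2 (0.72 log units; beyond the scatter), ethyl in place of hydrogen on a saturated chain carbon bound to an aromatic nitrogen, lies beyond it. Compound 4 `Cc1c(C(=O)Nc2ccc(Oc3ncnc4[nH]cc(-c5ccccc5)c34)c(F)c2)c(=O)c2cc(OC(F)(F)F)ccc2n1C` differs from compound 1 by trifluoromethoxy in place of methyl on an aromatic carbon. Among the measured compounds shown here, the one measured step touching that same aromatic carbon was within the scatter, so in this assay at most a small shift is expected for compound 4. Compound 4 is therefore estimated at 150 nM, within 60 nM to 400 nM, a step of a 1.5-fold higher number from compound 1 to compound 4 (0.18 log units; within the scatter).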

Compound 4, half-maximal inhibitory concentration: 74 nM
Compound 4: the middle estimate sits 2.0-fold (0.31 log units) above what was measured; the range from low to high includes it.
By their numbers in this assay, from the lowest: compounds 4, 1 and 3 (each within the scatter of the next, the first and the last beyond it); then compound 2.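

Until compound 4, every compound shown carried methyl on this aromatic carbon of the core. In this assay, trifluoromethoxy, with 5 heavy atoms where methyl has 1, gives a 1.4-fold lower number from compound 1 to compound 4 (0.13 log units; within the scatter), so this larger group at this position leaves the number within the scatter. No measurement on hand explains this result.

Among these compounds, with only two groups compared at this carbon, no trend can be drawn. Going by these compounds, how hydrogen, an amine, a carboxylic acid or a longer chain would fare at this position remains open.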